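Lengthening the isothiocyanate chain once more

The source may report more compounds than this note shows. Statements on the series, on what has been measured and on what is new or still open speak of the compounds shown alone.

Compound 3 `CN(C)C(=O)c1cc2cnc(Nc3ccc(C(=O)NCCCCN=C=S)cc3)nc2n1C1CCCC1` was tested in a functional assay on NCI-H1299 cells (Homo sapiens) for inhibition, read by CCK-8 assay, with a stated time of 72 h, tested at 10 uM (on this read-out higher numbers stand for a stronger effect at the one concentration tested and lower numbers for a weaker effect), where compound 3 gives 74.2%. Among the three numbers measured this stands second highest: compound 1 `CN(C)C(=O)c1cc2cnc(Nc3ccc(S(=O)(=O)NCCCN=C=S)cc3)nc2n1C1CCCC1` gives 72.8%, which is a number 1.4 percentage points higher from compound 1 to compound 3 (within the scatter), while compound 2 `CN(C)C(=O)c1cc2cnc(Nc3ccc(C(=O)NCCCN=C=S)cc3)nc2n1C1CCCC1` gives 91.2%, which is a number 17 percentage points lower from compound 2 to compound 3 (beyond the scatter). For comparison, a number 18.4 percentage points higher from compound 1 to compound 2 (beyond the scatter).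

Compound 4 `CN(C)C(=O)c1cc2cnc(Nc3ccc(C(=O)NCCCCCN=C=S)cc3)nc2n1C1CCCC1` has not been measured. Its difference from compound 3 is a group of 4 heavy atoms (2 carbon, 1 nitrogen, 1 sulfur; no ring) in place of a group of 3 heavy atoms (1 carbon, 1 nitrogen, 1 sulfur; no ring), on a saturated chain carbon, four bonds along the chain from an amide-type nitrogen. Within the data shown here, the one measured step of the same kind is the chain extension from compound 2 to compound 3, where a number 17 percentage points lower from compound 2 to compound 3 (beyond the scatter), a modest drop. Among the measured compounds shown here, only one such step exists, so whether adding a further link in the chain continues that trend is uncertain; the change is expected to give a small fall or none beyond the scatter in this assay.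

Compound 4 is therefore estimated at 65% in this assay, within a range of 50% to 80%, which amounts to an expected step of a number 9.2 percentage points lower from compound 3 to compound 4 (within the scatter).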

Compound 4, a percentage reported as inhibition, at one concentration (the size of the read-out at that concentration, not a potency): 76.5%
The estimate for compound 4 lay 11.5 percentage points below the measured number, within the range that was stated.
By their numbers in this assay, from the lowest: compounds 1, 3 and 4 (each within the scatter of the next); then compound 2.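

In this assay, adding one more link to the isothiocyanate chain gives a number 2.3 percentage points higher from compound 3 to compound 4 (within the scatter), so the fall seen on the first extension does not continue at this position. The longer chain still shows a number 14.7 percentage points lower from compound 2 to compound 4 (beyond the scatter) and sits close to the sulfonamide-linked compound, with a number 3.7 percentage points higher from compound 1 to compound 4 (within the scatter), which makes the shorter chain of compound 2 the one that stands out among the amides, while the two longer chains cannot be told apart. Nothing available here explains why that shorter chain stands apart.

The compounds shown leave open whether a still shorter chain would match or pass compound 2. They also leave open whether the isothiocyanate itself matters, which an amine or a carboxylic acid in its place at the end of the chain would test.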